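Amide hydrogen and agonist potency in a shared core

The source may hold more compounds than are shown below. What is called first, only, known or untested is meant among the compounds shown, and "the series" means these compounds.

Compound 1 `CCCCNc1nc(N)nc2cccc(C(=O)NCc3ccccc3)c12` anchors the pair; in an ADME assay on HEK293 cells for agonist activity at Toll-like receptor 8 (Homo sapiens), read by a luciferase reporter, with a stated time of 6 h (a lower number here means that less compound is needed, a higher number that more compound is needed for the effect), compound 1 gives 1.6 uM. Compound 2 `CCCCNc1nc(N)nc2cccc(C(=O)N(C)Cc3ccccc3)c12` carries methyl in place of hydrogen on an amide-type nitrogen. In this assay compound 2 reaches only a limit of the assay, > 25 uM. Going by the values given here, the single measured step, an at least 15-fold higher number from compound 1 to compound 2 (1.19 log units; beyond the scatter), is therefore bounded from below only, resting on (the limit of > 25 uM in this assay, at which 1 of the 2 values shown sits). Compound 3 `CCCCNc1nc(N)nc2cccc(C(=O)N[C@H](C)c3ccccc3)c12` differs from compound 2 by (1-phenylethyl)amino in place of benzyl(methyl)amino on a carbonyl carbon. The change returns the amide hydrogen that compound 2 lacks and places the methyl within the (1-phenylethyl)amino group instead. Among the compounds with values here, the one step that bears on this, from compound 1 to compound 2, was large when the amide hydrogen was lost; its reversal is expected to bring a large step downward, an at least 10-fold lower number from compound 2 to compound 3 (1.00 log units; beyond the scatter). Compound 3 is accordingly estimated at 2.5 uM, with a range from 0.7 uM to 10 uM.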

Compound 3, minimum effective concentration: > 25 uM
Compound 3: no number, only a limit; the forecaster's own chance of this, stated with the estimate: 15%; middle value at least 10-fold (1.00 log units) away from the limit.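

In this assay, methyl in place of hydrogen on the saturated chain carbon bound to the amide-type nitrogen and the aromatic carbon gives an at least 15-fold higher number from compound 1 to compound 3 (1.19 log units; beyond the scatter), even though the amide hydrogen is still present. Going by these compounds alone, the amide hydrogen alone is therefore not enough to keep the activity of compound 1, and the earlier pair could not show this, since its only change removed that hydrogen. The step between compound 2 and compound 3 cannot be read, and both steps from compound 1 are bounded from below only: the limit of > 25 uM in this assay, at which 2 of the 3 values shown sit.

As far as these compounds go, how far compound 2 and compound 3 lie beyond that limit remains open. Also open, from the compounds shown here alone, is whether the opposite configuration at the defined stereocentre, or an ethyl or hydroxymethyl group in place of this methyl, would behave the same way.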